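The source may report more compounds than this note shows. Statements on the series, on what has been measured and on what is new or still open speak of the compounds shown alone.

Measured compounds:
compound 1 `CCCCN(CCCC)c1nc2c(ncn2-c2ccccc2)c(=O)n1-c1ccccc1` gives 20400 nM in a functional assay on HepG2 cells (Homo sapiens) for cytotoxicity, read by MTT assay, with a stated time of 72 h; a lower number here means a stronger inhibitor, a higher number a weaker inhibitor;
compound 2 `O=c1c2ncn(-c3ccccc3)c2nc(N2CCCCC2)n1-c1ccc(Cl)cc1` gives in this assay a value that is a limit, > 100000 nM;
compound 3 `CNc1nc2c(ncn2-c2ccccc2)c(=O)n1-c1ccccc1` gives in this assay a value that is also a limit, > 100000 nM.

Compound 2 therefore stands not with compound 1 but at the limit of > 100000 nM in this assay, at which 2 of the 3 values shown sit, together with compound 3; nothing more than that limit is known about it.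

Compound 4 `CCCCNc1nc2c(ncn2-c2ccccc2)c(=O)n1-c1ccc(Cl)cc1` differs from compound 2 in one place: butylamino in place of piperidin-1-yl on an aromatic carbon. The measured step that bears on this change is an at least 4.9-fold higher number from compound 1 to compound 3 (0.69 log units; beyond the scatter), where a dialkylamino group gave way to a single, shorter alkylamino group and the number rose beyond the scatter. The change from compound 2 to compound 4 runs in the same sense, from piperidin-1-yl to butylamino, so no gain is expected from it. Because compound 2 already sits at the limit of > 100000 nM in this assay, at which 2 of the 3 values shown sit, a step of the size seen from compound 1 to compound 3 could not be read as a number at all.

Compound 4 is expected to remain at the limit, with an estimated step that the limit leaves unreadable from compound 2 to compound 4. The estimate for compound 4 is 150000 nM, with a range from 50000 nM to 500000 nM.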

Compound 4, half-maximal inhibitory concentration: 77600 nM
The estimate for compound 4 lay 1.9-fold (0.29 log units) above the measured number, and the stated range covers the measured number.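

With butylamino in place of piperidin-1-yl on the aromatic carbon between two ring nitrogen atoms, compound 4 gives a readable number in this assay, so a compound with a 4-chlorophenyl group can leave the limit with a suitable group at this place, something compound 2 did not show. The change itself can be sized only in part: the data give an at least 1.2-fold lower number from compound 2 to compound 4 (0.11 log units; that floor lies within the scatter), which fixes a floor and does not establish a real gain from swapping the ring for the open chain. That floor rests on a limit on one side: the limit of > 100000 nM in this assay, at which 2 of the 4 values shown sit.

The compounds shown leave open whether the open butyl chain or the hydrogen-bond donor that butylamino carries and piperidin-1-yl lacks goes with the readable number, a question that a dibutylamino group on the core of compound 4 would help to answer. Also open, from the compounds shown here alone, is how a longer chain, a morpholine ring or a pyrrolidine ring at this place would read in this assay.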